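A few compounds are considered here, and "the series" means these few. Any claim that something is new, unique, unknown or untested is made for them only; others in the source may bear on it.

Compound 1 `C=CCNc1nc(N)c(C(=O)N=C(N)N)nc1Cl`: 78%
Compound 2 `NC(N)=NC(=O)c1nc(Cl)c(NCc2ccc(Cl)cc2)nc1N`: 97%
Compound 3 `CN(c1nc(N)c(C(=O)N=C(N)N)nc1Cl)C1CCCCC1`: 57%

In an assay for inhibition of acid-sensing ion channel 3 (Homo sapiens), read by patch clamp, tested at 20 uM (on this read-out lower numbers stand for less inhibition and higher numbers for more inhibition at the one concentration tested (going by the name of the read-out)), compound 1 gives 78%, the second highest of the three numbers: compound 2 gives 97%, and compound 3 gives 57%. Compound 4 `NC(N)=NC(=O)c1nc(Cl)c(N2CCCCC2)nc1N` has not yet been measured. It differs from compound 1 by piperidin-1-yl in place of allylamino on an aromatic carbon.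

Within the data shown here, only one measured step bears on this change, and only loosely: a number 19 percentage points higher from compound 1 to compound 2 (beyond the scatter), a change on the saturated chain carbon bound to the nitrogen that keeps that nitrogen's hydrogen. The step to compound 4 instead removes the hydrogen-bond donor and closes a ring on the nitrogen, and the closest measured analogue is compound 3, whose nitrogen also carries no hydrogen and which gives 57%, a lower number than compound 1. On that basis compound 4 is expected to sit below compound 1, with a step of about a number 18 percentage points lower from compound 1 to compound 4 (beyond the scatter). The estimate for compound 4 is 60%, within a range from 45% to 75%.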

Compound 4, a percentage reported as inhibition, at one concentration (the size of the read-out at that concentration, not a potency): 85%
Estimate against measurement, compound 4: 25 percentage points below; measured number outside the range, above it.
By their numbers in this assay, from the lowest: compound 3; then compounds 1 and 4 (each within the scatter of the next); then compound 2.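

In this assay, putting piperidin-1-yl in place of allylamino gives a number 7 percentage points higher from compound 1 to compound 4 (within the scatter) and so no change beyond the scatter, although a six-membered non-aromatic ring replaces the open chain and the hydrogen-bond donor count of the group falls to zero. Before this result, the only compound shown without a hydrogen on this nitrogen was compound 3 at 57%, whereas compound 4 at 85% shows that such a nitrogen can also go with a number in the range of compound 1. Nothing measured here explains why the change leaves the number within the scatter.

The compounds shown leave open whether other rings at this aromatic carbon, such as pyrrolidin-1-yl or morpholin-4-yl, would behave like piperidin-1-yl. They also leave open how an open-chain dimethylamino group would compare.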